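From compound 2 to compound 4: an acetyl exchange

This account rests on a few compounds, and the source may have more. Where it says the series, first, only, none or still open, it means among the compounds named here.

compound 1 `CC(=O)c1ccc(NC(=O)Cn2nc(-c3ccc(Cl)cc3)nc2N)cc1`: 20.6%
compound 2 `C/C(=N/O)c1ccc(NC(=O)Cn2nc(C(F)(F)F)nc2N)cc1`: 15.1%
compound 3 `C/C(=N/O)c1ccc(NC(=O)Cn2nc(-c3ccccc3)nc2N)cc1`: 15.4%

These three values come from a functional assay on UO-31 cells (Homo sapiens) for inhibition, read by sulforhodamine B assay, with a stated time of 48 h, tested at 10 uM; on this read-out lower numbers stand for less inhibition of growth and higher numbers for more inhibition of growth at the one concentration tested. Compound 2 lies within the scatter of both compound 3 and compound 1, so the three measured compounds cannot be ranked on this evidence.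

Compound 4 `CC(=O)c1ccc(NC(=O)Cn2nc(C(F)(F)F)nc2N)cc1` has not yet been measured. It differs from compound 2 by a group of 3 heavy atoms (2 carbon, 1 oxygen; no ring) in place of a group of 4 heavy atoms (2 carbon, 1 nitrogen, 1 oxygen; no ring), on an aromatic carbon. The incoming group is acetyl, and it sits para to a large group.

Going by the values given here, no measured step isolates this exchange. Among the compounds with values here, the only step available, a number 0.3 percentage points higher from compound 2 to compound 3 (within the scatter), concerns a different place on the molecule and stays within the scatter. Compound 1 already carries acetyl and gives 20.6%, which is also within the scatter of compound 2, although it differs from compound 2 in a second place as well.

No step beyond the scatter is therefore expected in this assay, and no firm direction can be assigned. The expected change is a number 1.4 percentage points higher from compound 2 to compound 4 (within the scatter), a small estimate that is not a predicted trend. For compound 4 the estimated value is 16.5%, with an expected range of 6% to 28%.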

Compound 4, percent growth inhibition at one concentration: 13.7%
Compound 4: middle estimate off by 2.8 percentage points, on the high side, within the range that was stated.
By their numbers in this assay, from the lowest: compounds 4, 2, 3 and 1 (each within the scatter of the next).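

With trifluoromethyl held constant, the acetyl exchange on this aromatic carbon, para to a large group, now has a step of its own in this assay (a number 1.4 percentage points lower from compound 2 to compound 4 (within the scatter)). The entering acetyl has no hydrogen-bond donor where the leaving group has one, yet this step stays within the scatter. With acetyl held constant, trifluoromethyl in place of 4-chlorophenyl also stays within the scatter (a number 6.9 percentage points lower from compound 1 to compound 4 (within the scatter)), so neither exchange separates the compounds on this read-out. No measurement is available that could explain these results.

The compounds shown leave open whether a different group at this position, such as an amine or a carboxylic acid, would give a step beyond the scatter. They also leave open how these exchanges would read at other concentrations or in other cell lines.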